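The compounds below may be only part of what the source reports. "The series", "measured", "known", "first", "only" and "open" are said of these compounds alone.

In a functional assay on A549 cells (Homo sapiens) for inhibition, read by sulforhodamine B assay, with a stated time of 74 h (a lower number here means a stronger inhibitor, a higher number a weaker inhibitor), compound 1 `Cc1ccc(S(=O)(=O)N2C(=O)COC23C=CC(=O)C=C3)cc1` gives 110 nM. Compound 3 `O=C1C=CC2(C=C1)OCC(=O)N2S(=O)(=O)c1ccc(N2CCCC2=O)cc1` gives 5 nM, which leaves compound 1 with the higher of the two actual numbers. Compound 2 `COc1ccc(S(=O)(=O)N2C(=O)COC23C=CC(=O)C=C3)cc1` reports only a limit, > 10000 nM. Compound 4 `O=C1C=CC2(C=C1)OCC(=O)N2S(=O)(=O)c1ccc(Br)s1` has not yet been measured. It has 5-bromothiophen-2-yl in place of 4-methylphenyl on a sulfonyl sulfur.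

Two measured changes to compound 1 bear on this, though both only replace the methyl on an aromatic carbon and keep the six-membered ring. Methoxy gives an at least 90-fold higher number from compound 1 to compound 2 (1.95 log units; beyond the scatter), while 2-oxopyrrolidin-1-yl gives a 22-fold lower number from compound 1 to compound 3 (1.34 log units; beyond the scatter). These large steps run in opposite directions, so this small series shows that the readout responds strongly to changes in this part of the molecule but gives no direction for a ring exchange. No step beyond the scatter is therefore expected, although a large move either way remains possible, and the expected change is no change at the digits printed from compound 1 to compound 4 (within the scatter). The estimate for compound 4 is 110 nM, with an expected range of 10 nM to 1500 nM.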

Compound 4, half-maximal inhibitory concentration: 50 nM
Compound 4: the middle estimate sits 2.2-fold (0.34 log units) above what was measured; low and high end bracket the measured number.
By their numbers in this assay, from the lowest: compound 3; then compound 4; then compound 1. At a limit, above all of these: compound 2.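

Putting 5-bromothiophen-2-yl in place of 4-methylphenyl on the sulfonyl sulfur gives a 2.2-fold lower number from compound 1 to compound 4 (0.34 log units; beyond the scatter) in this assay, the first change shown that replaces the whole aromatic group rather than only the methyl on it. A six-membered aromatic ring of carbon only is therefore not required at this position for a nanomolar number, and this exchange moves the readout modestly, whereas the two substituent changes on the six-membered ring both gave large steps. No measurement shown gives a cause for this step.

Going by these compounds, it remains open whether the bromine or the five-membered ring accounts for the step, which 5-chlorothiophen-2-yl or unsubstituted thiophen-2-yl could address. Also open, on these data alone, is how furan-2-yl, or an amine or a carboxylic acid on the five-membered ring, would read.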